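The source may report more compounds than this note shows. Statements on the series, on what has been measured and on what is new or still open speak of the compounds shown alone.

Measured compounds:
- compound 1 `O=C(CCCCCNc1c(NCc2ccccc2)c(=O)c1=O)NO`: < 4.8 uL/min
- compound 2 `C[C@@H](Nc1c(NCCCCCC(=O)NO)c(=O)c1=O)c1ccccc1`: < 5 uL/min
- compound 3 `C[C@H](Nc1c(NCCCCCC(=O)NO)c(=O)c1=O)c1ccccc1`: < 5 uL/min

In an ADME assay on cells (Hepatocyte, Homo sapiens) for pharmacokinetics, read by LC-MS, with a stated time of 90 min, tested at 1 uM (on this read-out lower numbers stand for slow clearance and higher numbers for fast clearance), compound 3 gives < 5 uL/min, which is a limit of the assay and not a number. Compound 1 likewise sits at a limit, (the limit of < 4.8 uL/min in this assay, at which 1 of the 3 values shown sits). Compound 2 also sits at a limit, (the limit of < 5 uL/min in this assay, at which 2 of the 3 values shown sit). So the steps a step that the two limits leave unreadable from compound 1 to compound 3 and a step that the two limits leave unreadable from compound 2 to compound 3 cannot be read, and the fact that compounds 2 and 3 differ only in the configuration as drawn adds no readable size either. Compound 4 `Cc1ccccc1Nc1c(NCCCCCC(=O)NO)c(=O)c1=O` differs from compound 3 by 2-methylphenyl in place of 1-phenylethyl on a nitrogen on an aromatic ring. Among the compounds with values here, no measured step gives a readable size for this kind of change, so the account can only expect compound 4 to stay in the same region as compound 3, with the estimated step that the limit leaves unreadable from compound 3 to compound 4. Compound 4 is therefore estimated at 4 uL/min, between 1.5 uL/min and 12 uL/min, most probably reported again as a limit.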

Compound 4, intrinsic clearance in a liver preparation (reported as CLH), per the amount of preparation that the assay uses: < 5 uL/min
Compound 4: only a limit was reported; the forecaster's own chance of this, stated with the estimate: 65%; the middle value is on the limit's open side.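

Within the data shown here, compound 4, like compound 1, compound 2 and compound 3, gives only a limit in this assay, so no step among them can be read. The compounds shown leave open how large these steps are.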